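The source may report more compounds than this note shows. Statements on the series, on what has been measured and on what is new or still open speak of the compounds shown alone.

Among the measured compounds shown here, in a functional assay on U-87MG ATCC cells (Homo sapiens) for antiproliferative activity, with a stated time of 3 days (a lower number here means that less compound is needed, a higher number that more compound is needed for the effect), compound 2 (`Oc1ccc(CN(CCN2CCCC2)Cc2ccc(O)c3ncccc23)c2cccnc12`) gives 0.2 uM, the lower of the two numbers measured so far. For the measured compounds named here, the only other measured compound is compound 1 (`Oc1ccc(CN(Cc2cccc(I)c2)Cc2ccc(O)c3ncccc23)c2cccnc12`), which gives 2 uM. Compound 3 (`Oc1ccc(CN(Cc2ccc(O)c3ncccc23)Cc2ccc(O)c3ncccc23)c2cccnc12`) still awaits measurement. It keeps the shared core, and one arm changes: 8-hydroxyquinolin-5-yl in place of (pyrrolidin-1-yl)methyl on a saturated chain carbon bound to an amine nitrogen. So 8-hydroxyquinolin-5-yl stands in place of (pyrrolidin-1-yl)methyl on a saturated chain carbon bound to an amine nitrogen. Going by the values given here, only one measured step bears on this: a 10-fold lower number from compound 1 to compound 2 (1.00 log units; beyond the scatter). That step swapped 3-iodophenyl for (pyrrolidin-1-yl)methyl, while compound 3 makes a swap in the opposite sense, giving up the pyrrolidine group for an aromatic one. A single step is thin support, and 8-hydroxyquinolin-5-yl is not 3-iodophenyl, so only part of that gap is expected to return. The expected change in this assay is a 5.0-fold higher number from compound 2 to compound 3 (0.70 log units; beyond the scatter), toward a higher number. Compound 3 is estimated at 1 uM, with an expected range of 0.25 uM to 4 uM.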

Compound 3, concentration for half-maximal effect: > 10 uM
Compound 3 gave a limit, no number; the forecaster's own chance of this, stated with the estimate: 3%; middle value at least 10-fold (1.00 log units) from the limit.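

In this assay compound 3 gives only a limit of the assay, not a number: the limit of > 10 uM in this assay, at which 1 of the 3 values shown sits. Putting 8-hydroxyquinolin-5-yl in place of (pyrrolidin-1-yl)methyl on a saturated chain carbon bound to an amine nitrogen brings an at least 50-fold higher number from compound 2 to compound 3 (1.69 log units; beyond the scatter), a larger step than the one that first separated the pyrrolidine arm from an aromatic arm. Aromatic arms are also not interchangeable at this place, since replacing 3-iodophenyl with 8-hydroxyquinolin-5-yl gives an at least 5.0-fold higher number from compound 1 to compound 3 (0.69 log units; beyond the scatter), which leaves the pyrrolidine arm with the lowest number of the three.

The compounds shown cannot tell whether the pyrrolidine ring itself matters or whether another amine on the same chain, such as piperidine, morpholine or dimethylamino, would do as well. On these data alone, the effect of a longer or shorter chain between the amine nitrogen and the pyrrolidine also stays open.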